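A Dibromophenyl Amide Built on an Inactive Scaffold

This account rests on a few compounds, and the source may have more. Where it says the series, first, only, none or still open, it means among the compounds named here.

Compound 1, `O=C(Nc1ccc(Sc2nc3ccccc3s2)c(Cl)c1)c1ccccc1O`: > 100000 nM
Compound 2, `O=C(Nc1ccc(Sc2nc3ccccc3s2)cc1)c1ccccc1O`: > 100000 nM
Compound 3, `O=C(Nc1cccc(Cl)c1)c1cccc(Br)c1`: > 100000 nM

In an assay for inhibition of HSP60/HSP10 (Homo sapiens), with a stated time of 60 min (on this read-out lower numbers stand for stronger inhibition and higher numbers for weaker inhibition), compound 1 gives > 100000 nM, which is a limit of the assay and not a number. Compound 2 gives > 100000 nM, again only a limit. Compound 3 also stops at a limit, > 100000 nM. Among the compounds with values here, every value so far sits at the limit of > 100000 nM in this assay, at which 3 of the 3 values shown sit. The step that the two limits leave unreadable from compound 1 to compound 2 is therefore unreadable, and compound 2 stands at the limit with nothing to rank it against the others.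

Compound 4, `O=C(Nc1ccc(Sc2nc3ccccc3s2)cc1)c1cc(Br)cc(Br)c1`, differs from compound 2 in one place: 3,5-dibromophenyl in place of 2-hydroxyphenyl on a carbonyl carbon. No measured step covers an exchange of this kind, and the single step shown gives no readable size. With all three measured compounds at the limit, the most likely outcome is that compound 4 also returns only a limit. The estimated step of a number no higher from compound 2 to compound 4 (the limit leaves the size open) means no movement beyond the scatter. Compound 4 is accordingly estimated at 100000 nM, within 30000 nM to 300000 nM.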

Compound 4, half-maximal inhibitory concentration: > 100000 nM
Compound 4: no number, only a limit; the forecaster's own chance of this, stated with the estimate: 80%; the middle value sits exactly at the limit.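

Compound 4 gives > 100000 nM in this assay, which is a limit and not a number. The step between compound 2 and compound 4 therefore cannot be read, and the same holds for every compound shown: the limit of > 100000 nM in this assay, at which 4 of the 4 values shown sit.

Going by these compounds, what stays open is how these compounds rank against one another, and which change would give a readable number.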